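Trading Chloro for Trifluoromethyl in a Mouse Exposure Study

The compounds below may be only part of what the source reports. "The series", "measured", "known", "first", "only" and "open" are said of these compounds alone.

Going by the values given here, only two compounds have numbers so far, so any forecast rests on thin ground. In an ADME assay on the whole organism (plasma, strain Balb) for pharmacokinetics, with Mus musculus as the target, at a dose of 10 mg/kg by the oral route (a lower number here means less compound in the circulation, a higher number more compound in the circulation at the dose given), compound 1 (`NC(=O)c1cc(-c2ccnc(N)n2)[nH]c1-c1cc(C(F)(F)F)ccc1Cl`) reaches 3630 ng.h/mL while compound 2 (`CCc1ccc(Cl)cc1-c1[nH]c(-c2ccnc(N)n2)cc1C(N)=O`) gives 239 ng.h/mL and so holds the lower of the two numbers, by a gap well beyond the usual scatter.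

The next compound to be tested is compound 3 (`CCc1ccc(C(F)(F)F)cc1-c1[nH]c(-c2ccnc(N)n2)cc1C(N)=O`). It is compound 2 with trifluoromethyl in place of chloro on an aromatic carbon, para to an ethyl group (trifluoromethyl in place of chloro on an aromatic carbon). Among the compounds with values here, no two measured compounds differ in one place only, so the data offer no direct guide to what this single change does. Within the data shown here, the one hint is that compound 1 also carries trifluoromethyl and gives 3630 ng.h/mL in this assay (a weak clue, since other parts of the structure differ too). A moderate rise that only just clears the scatter is expected (a 2.5-fold higher number from compound 2 to compound 3 (0.40 log units; beyond the scatter)) and a result within the scatter would be no surprise. Compound 3 is estimated to give 600 ng.h/mL (expected range 150 ng.h/mL to 2400 ng.h/mL).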

Compound 3, area under the concentration-time curve: 1730 ng.h/mL
The estimate for compound 3 lay 2.9-fold (0.46 log units) below the measured number; the range from low to high includes it.
By their numbers in this assay, from the lowest: compound 2; then compound 3; then compound 1.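

Placing trifluoromethyl in place of chloro on the aromatic carbon para to an ethyl group gives a 7.2-fold higher number from compound 2 to compound 3 (0.86 log units; beyond the scatter) in this assay, the first direct reading of this change, from a pair that differs in one place only. The second pair keeps trifluoromethyl on both sides and changes another place on the same ring: ethyl in place of chloro on an aromatic carbon gives a 2.1-fold lower number from compound 1 to compound 3 (0.32 log units; beyond the scatter), so the ring substituent at that other place also shifts the exposure reading beyond the scatter. No supporting measurement is available to explain what lies behind either step.

As far as these compounds go, with three compounds, each change has been read in a single pair, so it remains open whether trifluoromethyl in place of chloro would give a step of similar size with something other than ethyl on the ring. From the compounds shown here alone, how a fluoro group, a methoxy group or a nitrile would fare at the trifluoromethyl position, or a propyl chain in place of ethyl, also remains open.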